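Swapping the Aniline on a Shared Core: Compound 3 Foreseen

The source may report more compounds than this note shows. Statements on the series, on what has been measured and on what is new or still open speak of the compounds shown alone.

Measured so far:
Compound 1 `COc1cc2ncnc(Nc3cccc(Cl)c3)c2cc1OCCCCC(=O)Nc1ccc(S(N)(=O)=O)cc1` gives 30400 nM in a functional assay on A-431 cells (Homo sapiens) for antiproliferative activity, read by MTT assay, with a stated time of 72 h; on this read-out higher numbers stand for weaker inhibition and lower numbers for stronger inhibition.
Compound 2 `COc1cc2ncnc(Nc3cccc(Cl)c3F)c2cc1OCCCCC(=O)Nc1ccc(S(N)(=O)=O)cc1` gives 5560 nM in this assay.

Going by the values given here, compound 2 holds the lower of the two numbers seen; the only measured step, a 5.5-fold lower number from compound 1 to compound 2 (0.74 log units; beyond the scatter), separates it from compound 1, and that step was modest though beyond the scatter. Compound 3 `COc1cc2ncnc(Nc3ccc(C(F)(F)F)cc3)c2cc1OCCCCC(=O)Nc1ccc(S(N)(=O)=O)cc1` carries a different change: 4-(trifluoromethyl)phenyl in place of 3-chloro-2-fluorophenyl on a nitrogen on an aromatic ring. Among the compounds with values here, no measured step describes this exchange; the step from compound 1 to compound 2 concerns only one added fluorine on the aniline ring and therefore does not bear directly on replacing the whole 3-chloro-2-fluorophenyl with 4-(trifluoromethyl)phenyl. Within the data shown here, the expectation for compound 3 can rest only on the fact that both measured numbers lie in a weak range and that the sole measured change moved the number by a modest amount. Compound 3 is therefore expected to show a weaker number than compound 2, estimated as a 4.5-fold higher number from compound 2 to compound 3 (0.65 log units; beyond the scatter). The estimate for compound 3 in this assay is 25000 nM, within 6000 nM to 100000 nM.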

Compound 3, half-maximal inhibitory concentration: 16900 nM
Compound 3: the middle estimate sits 1.5-fold (0.17 log units) above what was measured; the measured number falls inside the stated range.
By their numbers in this assay, from the lowest: compound 2; then compounds 3 and 1 (each within the scatter of the next).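

In this assay, putting 4-(trifluoromethyl)phenyl in place of 3-chloro-2-fluorophenyl on the nitrogen gives a 3.0-fold higher number from compound 2 to compound 3 (0.48 log units; beyond the scatter), so exchanging the whole aniline ring at this position changes the number only modestly, as the single added fluorine did earlier. Putting the same group in place of 3-chlorophenyl gives a 1.8-fold lower number from compound 1 to compound 3 (0.25 log units; within the scatter), which lies within the scatter, so the new ring is separated from the 3-chloro-2-fluorophenyl ring but not from the 3-chlorophenyl ring. Nothing available explains either step.

The compounds shown leave open how a pyridine ring or a benzyl group would read on this nitrogen. They also leave open what a carboxylic acid or an amine in place of the sulfonamide would do to the number.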